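The source may report more compounds than this note shows. Statements on the series, on what has been measured and on what is new or still open speak of the compounds shown alone.

Measured so far in a functional assay on PC-3 cells (Homo sapiens) for cytotoxicity, read by MTT assay, with a stated time of 48 h; on this read-out lower numbers stand for stronger inhibition and higher numbers for weaker inhibition:
compound 1 `CC1=NN(C(=O)COc2ccc(Cl)cc2)C(c2cc(Br)ccc2O)C1`: 49000 nM
compound 2 `CC1=NN(C(=O)CN2CCN(C)CC2)C(c2ccccc2O)C1`: 11800 nM
compound 3 `O=C(CCl)N1N=C(c2cc3ccccc3oc2=O)CC1c1ccccc1`: 2980 nM

Compound 3 gives the lowest number of the three. Compound 2 stands a step above it that lies beyond the usual scatter, and compound 1 stands further above still, also beyond it; compound 3 is therefore the most potent of the measured set. Compound 4 `CC(C)(C)NCC(=O)N1N=C(c2cc3ccccc3oc2=O)CC1c1ccccc1` has not yet been run in this assay. It differs from compound 3 in one place: (tert-butyl)amino in place of chloro on a saturated chain carbon bound to a carbonyl carbon. For the measured compounds named here, no pair of measured compounds shows this same change; its size is not known from them. A modest weakening is expected, a step of a 2.0-fold higher number from compound 3 to compound 4 (0.30 log units; within the scatter). For compound 4 the estimate is 6000 nM, with a range from 1500 nM to 25000 nM.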

Compound 4, half-maximal inhibitory concentration: 16400 nM
Compound 4: the middle estimate sits 2.7-fold (0.44 log units) below what was measured; measured number inside the range.
By their numbers in this assay, from the lowest: compound 3; then compounds 2 and 4 (each within the scatter of the next); then compound 1.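

In this assay the saturated chain carbon bound to a carbonyl carbon proves sensitive to what it carries: (tert-butyl)amino in place of chloro gives a 5.5-fold higher number from compound 3 to compound 4 (0.74 log units; beyond the scatter) and this modest loss lies beyond the scatter. The chloro of compound 3 therefore cannot be exchanged for this amine at this place without cost on the shared core. Nothing at hand gives a reason for the step.

From the compounds shown here alone, whether the loss belongs to the amine nitrogen or to the tert-butyl stays open. A methylamino group at this place would separate the two, and a bromo group would test whether the chloro itself can be varied.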